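A few compounds are considered here, and "the series" means these few. Any claim that something is new, unique, unknown or untested is made for them only; others in the source may bear on it.

Of the compounds shown here, three sharing one core have been measured in a functional assay on L5178Y cells (Mus musculus) for inhibition, read by MTT assay, with a stated time of 24 h; on this read-out lower numbers stand for stronger inhibition and higher numbers for weaker inhibition: compound 1 (`N/N=C1\C[C@@H](c2ccc(O)cc2)Oc2cc(O)cc(O)c21`), compound 2 (`Oc1ccc([C@@H]2C/C(=N\Nc3ccccc3)c3c(O)cc(O)cc3O2)cc1`) and compound 3 (`Oc1ccc([C@@H]2C/C(=N\Nc3cnccn3)c3c(O)cc(O)cc3O2)cc1`). Compound 1 stands at >= 11300 nM which is a limit of the assay and not a number. Compound 2 stands at >= 11300 nM which is again a limit. Compound 3 stands at >= 11300 nM which is also a limit, so it has no number of its own.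

The next compound is compound 4 (`Cn1cccc1/C=N/N=C1\C[C@@H](c2ccc(O)cc2)Oc2cc(O)cc(O)c21`). It differs from compound 3 in one place, on a double-bonded nitrogen (a group of 8 heavy atoms (6 carbon, 2 nitrogen; one five-membered aromatic ring with 1 hetero atom) in place of a group of 7 heavy atoms (4 carbon, 3 nitrogen; one six-membered aromatic ring with 2 hetero atoms), on a double-bonded nitrogen). Within the data shown here, three measured steps bear on that place (a step that the two limits leave unreadable from compound 1 to compound 2; a step that the two limits leave unreadable from compound 1 to compound 3; a step that the two limits leave unreadable from compound 2 to compound 3). None of them has a readable size, and the whole set rests on one shared value (the limit of >= 11300 nM in this assay, at which 3 of the 3 values shown sit). They therefore give no direction for a further exchange at this place in this assay and no sign that such an exchange matters. The new group is not a close match for any group already measured, so a real number cannot be ruled out. The expected outcome is still a step that the limit leaves unreadable from compound 3 to compound 4 with no clear change anticipated. For compound 4 the estimate is 12000 nM with an expected range from 5000 nM to 30000 nM and a good chance that it will give only a limit.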

Compound 4, half-maximal inhibitory concentration: >= 11300 nM
Compound 4 gave a limit, no number; the forecaster's own chance of this, stated with the estimate: 70%; the middle value does not contradict the limit.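

The steps from compound 1, compound 2 and compound 3 to compound 4 cannot be read, since compound 4, like the others, gave only a limit in this assay: the limit of >= 11300 nM in this assay, at which 4 of the 4 values shown sit.

The compounds shown leave open whether any exchange of group on the double-bonded nitrogen alters inhibition in this assay, and what real value each of the four compounds has.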